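The source may report more compounds than this note shows. Statements on the series, on what has been measured and on what is new or still open speak of the compounds shown alone.

The compounds measured in a functional assay on the whole organism (stomach) with Rattus norvegicus as the target; on this read-out higher numbers stand for an effect only at larger amounts of compound and lower numbers for an effect already at smaller amounts:
Compound 1 `N=C(S)CCCCn1nc(-c2ccccc2)ccc1=O` gives > 100 mg/kg, which is a limit of the assay.
Compound 2 `Cc1ccc(=O)n(CCCC(=N)S)n1` gives > 100 mg/kg, which is a limit of the assay.
Compound 3 `N=C(S)CCn1nc(-c2ccccc2)c2ccccc2c1=O` gives 66.5 mg/kg.

Compound 3 is the only one of the three to yield an actual number; the other two values rest at the limit of > 100 mg/kg in this assay, at which 2 of the 3 values shown sit. For the measured compounds named here, no pair of measured compounds differs in just one place, so no measured step shows how any single change shifts this assay. Compound 4 `N=C(S)CCn1ncc2ccccc2c1=O` is the next compound to be tested. It differs from compound 3 by hydrogen in place of phenyl on an aromatic carbon. Going by the values given here, with no measured step to lean on, the step from compound 3 to compound 4 is expected to be modest, towards an effect only at larger amounts, likely beyond the scatter: a 2.0-fold higher number from compound 3 to compound 4 (0.29 log units; within the scatter). Compound 4 is expected to give 130 mg/kg in this assay, within 50 mg/kg to 350 mg/kg.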

Compound 4, dose for half-maximal effect: 90.1 mg/kg
The estimate for compound 4 lay 1.4-fold (0.16 log units) above the measured number; the measured number falls inside the stated range.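

This is the first change in a single place among these compounds: in this assay, hydrogen in place of phenyl on an aromatic carbon next to the ring nitrogen gives a 1.4-fold higher number from compound 3 to compound 4 (0.13 log units; within the scatter). So at this position, losing the whole phenyl ring produces no shift that stands clear of the usual scatter. Compound 4, like compound 3, gives a number rather than resting at a limit: the limit of > 100 mg/kg in this assay, at which 2 of the 4 values shown sit.

On these data alone, what remains open is whether a different group at this position, such as an amine or a carboxylic acid, would move the number beyond the scatter. For the compounds shown here, the chain length also stays unresolved, since no single-place step isolates it.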